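This account rests on a few compounds, and the source may have more. Where it says the series, first, only, none or still open, it means among the compounds named here.

The compounds measured so far:
Compound 1, `Cc1cccc(-c2nnc(CSc3nnc(/N=C/c4ccccc4O)s3)o2)c1`, gives 24300 nM in a functional assay on A549 cells (Homo sapiens) for inhibition, read by CCK-8 assay; on this read-out higher numbers stand for weaker inhibition and lower numbers for stronger inhibition.
Compound 2, `Cc1ccc(-c2nnc(CSc3nnc(/N=C/c4ccccc4O)s3)o2)cc1`, gives 22000 nM in this assay.

Going by the values given here, compound 2 stands level with compound 1 on these numbers: the step of a 1.1-fold lower number from compound 1 to compound 2 (0.04 log units; within the scatter) is within the scatter, and these are the only two values known. Compound 3, `COc1ccc(-c2nnc(CSc3nnc(/N=C/c4ccccc4O)s3)o2)cc1`, has not been measured. It differs from compound 2 by methoxy in place of methyl on an aromatic carbon. Among the compounds with values here, no measured step bears directly on this change; the only step known, a 1.1-fold lower number from compound 1 to compound 2 (0.04 log units; within the scatter), concerns a different alteration of the same phenyl group and is itself within the scatter, so it offers no direction. With nothing in the measured pair to point one way or the other, the step of no change at the digits printed from compound 2 to compound 3 (within the scatter) in this assay is expected to be none beyond the scatter. Compound 3 is therefore estimated at 22000 nM, with a range from 9000 nM to 55000 nM.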

Compound 3, half-maximal inhibitory concentration: 20300 nM
The estimate for compound 3 lay 1.1-fold (0.03 log units) above the measured number, within the range that was stated.
By their numbers in this assay, from the lowest: compounds 3, 2 and 1 (each within the scatter of the next).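

In this assay, methoxy in place of methyl on the aromatic carbon para to a large group gives a 1.1-fold lower number from compound 2 to compound 3 (0.03 log units; within the scatter), so this position now has a second substituent, one carrying an oxygen that methyl lacks, with no step beyond the scatter. The comparison between the 3-methylphenyl and 4-methoxyphenyl compounds, a 1.2-fold lower number from compound 1 to compound 3 (0.08 log units; within the scatter), is also within the scatter, so all three compounds stand level on these numbers. Nothing available explains why these changes leave the number within the scatter.

The compounds shown leave open whether an amine, a carboxylic acid or a longer chain such as butoxy on this phenyl group would give a step beyond the scatter. They also say nothing about changes to the rest of the shared core, such as replacing its hydroxy group.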